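The source may report more compounds than this note shows. Statements on the series, on what has been measured and on what is new or still open speak of the compounds shown alone.

The measured compounds:
Compound 1 `CCc1c(Cc2ccccc2Br)nc(SCc2ccc(OC)cc2)[nH]c1=O` gives 165000 nM in an ADME assay on MT4 cells (Homo sapiens) for cytotoxicity, read by MTT assay; a lower number here means that less compound is tolerated, a higher number that more compound is tolerated.
Compound 2 `CCc1c(Cc2cc(C)cc(C)c2)nc(SCc2ccc(OC)cc2)[nH]c1=O` gives in this assay a value that is a limit of the assay, > 317000 nM.

Compound 2 thus stands only as a limit in this assay, sitting at the limit of > 317000 nM in this assay, at which 1 of the 2 values shown sits, and no number is known for it. Compound 3 `CCc1c(Cc2c(Cl)cccc2Cl)nc(SCc2ccc(OC)cc2)[nH]c1=O` is not yet measured; it differs from compound 2 by 2,6-dichlorophenyl in place of 3,5-dimethylphenyl on a saturated chain carbon bound to an aromatic carbon. Going by the values given here, the one measured step that bears on this change is an at least 1.9-fold higher number from compound 1 to compound 2 (0.28 log units; that floor lies within the scatter), an exchange of the ring on the same saturated chain carbon bound to an aromatic carbon. The change from compound 2 to compound 3 returns to a halogen-bearing ring of the kind carried by compound 1, which gives 165000 nM. The expected step is therefore small and, if anything, downward: an at least 1.5-fold lower number from compound 2 to compound 3 (0.20 log units; that floor lies within the scatter). Compound 3 is estimated at 200000 nM, in the range 80000 nM to 400000 nM, with a real chance that this assay again reports only a limit.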

Compound 3, half-maximal cytotoxic concentration: > 287000 nM
Compound 3: a limit, no number (the forecaster's own chance of this, stated with the estimate: 40%); middle value at least 1.4-fold (0.15 log units) away from the limit.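

Compound 3 also stands only as a limit in this assay: the limit of > 287000 nM in this assay, at which 1 of the 3 values shown sits. Set against 2-bromophenyl, the 2,6-dichlorophenyl ring gives an at least 1.7-fold higher number from compound 1 to compound 3 (0.24 log units; that floor lies within the scatter), so carrying halogen on this ring does not by itself bring a measured number, as compound 1 alone had suggested. Compound 2 and compound 3 are both limits, and the step between them cannot be read.

As far as these compounds go, what stays open is how far compound 2 and compound 3 truly lie from compound 1, and whether either gap reaches beyond the scatter. The compounds shown also do not tell how a ring bearing an amine or a carboxylic acid, in place of 2,6-dichlorophenyl on the same saturated chain carbon, would read in this assay.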